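Diaryl ether amides: methyl removal from the anilide ring

The source may hold more compounds than are shown below. What is called first, only, known or untested is meant among the compounds shown, and "the series" means these compounds.

Compound 1 `Cc1ccc(Oc2ccc(C(=O)N(C)c3cccc(C)c3)cc2)cc1` gives 26300 nM
Compound 2 `Cc1cccc(Oc2ccc(C(=O)N(C)c3cccc(C)c3)cc2)c1` gives 16100 nM

Both numbers come from an assay for inhibition of 17-beta-hydroxysteroid dehydrogenase type 1 (Homo sapiens), read by HPLC, with a stated time of 10 min; on this read-out higher numbers stand for weaker inhibition and lower numbers for stronger inhibition. On the numbers shown, compound 2 sits within the scatter of the only other value: a 1.6-fold lower number from compound 1 to compound 2 (0.21 log units; within the scatter). Compound 3 `Cc1cccc(N(C)C(=O)c2ccc(Oc3ccccc3)cc2)c1` differs from compound 2 in one place: hydrogen in place of methyl on an aromatic carbon. Within the data shown here, no measured step removes a methyl; the single measured step, a 1.6-fold lower number from compound 1 to compound 2 (0.21 log units; within the scatter), only moves one and stays within the scatter. Nothing therefore points to a step beyond the scatter, and none is expected: a 1.2-fold higher number from compound 2 to compound 3 (0.09 log units; within the scatter). Compound 3 is estimated at 20000 nM, expected between 8000 nM and 50000 nM.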

Compound 3, half-maximal inhibitory concentration: "not active" (no number reported)
The entry for compound 3 holds no number; the estimate stays without a comparison.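

In this assay, among these compounds, compound 3 is entered as "not active" without a number, so no step from compound 2 to compound 3 can be read. The size of any effect of the 3-methylphenoxy to phenoxy change remains open, and no further data explain this result.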